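The source may hold more compounds than are shown below. What is called first, only, known or untested is meant among the compounds shown, and "the series" means these compounds.

Compound 1 `COc1ccc2nc(C(=O)Nc3ccc(-c4ccccc4)cc3)c(C)c(O)c2c1` and compound 2 `Cc1c(C(=O)Nc2ccc(-c3ccccc3)cc2)nc2ccccc2c1O` differ only by hydrogen in place of methoxy on an aromatic carbon. In a functional assay on A-375 cells (Homo sapiens) for antiproliferative activity, read by MTT assay, with a stated time of 24 h, tested at 0.41 ug/mL (on this read-out higher numbers stand for a stronger effect at the one concentration tested and lower numbers for a weaker effect), compound 1 gives 7.62%, and compound 2 gives 2.65%. Of these two numbers compound 1 holds the upper one, but the step of a number 5 percentage points lower from compound 1 to compound 2 (within the scatter) means the two cannot be told apart. Compound 3 `COc1ccc2nc(C(=O)Nc3ccc(-c4ccccc4)cc3)c(C)c(C(=O)O)c2c1` differs from compound 1 by carboxy in place of hydroxy on an aromatic carbon. Among the measured compounds shown here, no measured step touches this position, so the one known step gives no guide. The expected step is a number 1.6 percentage points lower from compound 1 to compound 3 (within the scatter), nothing beyond the scatter. Compound 3 is therefore estimated at 6%, between -5% and 17%.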

Compound 3, a percentage reported as inhibition, at one concentration (the size of the read-out at that concentration, not a potency): 11.3%
The estimate for compound 3 lay 5.3 percentage points below the measured number; the measured number falls inside the stated range.
By their numbers in this assay, from the lowest: compounds 2, 1 and 3 (each within the scatter of the next).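

In this assay, putting carboxy in place of hydroxy gives a number 3.7 percentage points higher from compound 1 to compound 3 (within the scatter), the first step seen at this position, opposite the ring nitrogen. On this read-out, the two groups cannot be told apart here, so the position accepts the exchange without a clear change in effect at the one concentration tested. No supporting data bear on what lies behind this result. From the compounds shown here alone, what an amine or a methyl ester would give at this position stays open. So does whether other groups here would produce a step beyond the scatter.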